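The source may report more compounds than this note shows. Statements on the series, on what has been measured and on what is new or still open speak of the compounds shown alone.

Measured so far:
- compound 1 `COC(=O)C[C@H](NC(=O)OC(C)(C)C)C(=O)N(Cc1ccc(F)cc1)C1(C(=O)NCc2ccccc2)CCN(Cc2ccccc2)CC1`: > 100000 nM in an ADME assay on MDCK cells (Canis lupus familiaris) for cytotoxicity, read by microscopy, with a stated time of 72 h; a higher number here means that more compound is tolerated, a lower number that less compound is tolerated
- compound 2 `COC(=O)C[C@H](NC(=O)OC(C)(C)C)C(=O)N(Cc1ccc(C)cc1)C1(C(=O)NCc2ccccc2)CCN(Cc2ccccc2)CC1`: > 100000 nM in this assay

Both of these values are limits of the assay, not numbers. For compound 1 the value > 100000 nM is a limit. For compound 2 the value > 100000 nM is likewise a limit, so where compound 2 truly stands is not known beyond that. Among the measured compounds shown here, the only measured step, a step that the two limits leave unreadable from compound 1 to compound 2, therefore has no readable size, which is the whole content of the limit of > 100000 nM in this assay, at which 2 of the 2 values shown sit.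

Compound 3 `COC(=O)C[C@H](NC(=O)OC(C)(C)C)C(=O)N(Cc1ccc([N+](=O)[O-])cc1)C1(C(=O)NCc2ccccc2)CCN(Cc2ccccc2)CC1` differs from compound 2 by nitro in place of methyl on an aromatic carbon. For the measured compounds named here, no measured step bears on a nitro group entering in this way, so there is no basis for expecting a shift in either direction; the step of a number no higher from compound 2 to compound 3 (the limit leaves the size open) is simply expected to leave compound 3 at the limit as well. Compound 3 is estimated at 100000 nM, with a range from 40000 nM to 300000 nM.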

Compound 3, minimum cytotoxic concentration: 20000 nM
Compound 3: middle estimate off by 5.0-fold (0.70 log units), on the high side, and the stated range ends above it.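

With 4-nitrobenzyl, the series gains its first value that is a number rather than a limit, which shows that the group on this aromatic carbon can change how much compound the cells tolerate in this assay. Nitro in place of methyl gives an at least 5.0-fold lower number from compound 2 to compound 3 (0.69 log units; beyond the scatter), and nitro in place of fluoro gives an at least 5.0-fold lower number from compound 1 to compound 3 (0.69 log units; beyond the scatter). Both steps are minimum sizes only, and their true sizes stay unknown because each starts from a compound at the limit: the limit of > 100000 nM in this assay, at which 2 of the 3 values shown sit.

The compounds shown leave open whether this lower number belongs to nitro alone or would also come with other groups on the same carbon, such as an amine, a nitrile or a carboxylic acid. They also leave open whether nitro would give a similar step if another part of the shared core were changed.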